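This account rests on a few compounds, and the source may have more. Where it says the series, first, only, none or still open, it means among the compounds named here.

Measured compounds in an ADME assay on microsomes from liver (Rattus norvegicus) for metabolic stability, read by LC-MS; a lower number here means slower removal, a higher number faster removal of the compound:
compound 1 `COc1cc(N2CCN(C(=O)N[C@@H](C)c3cccc4ccccc34)CC2)ccc1-n1cnc(C)n1` gives 110 mL.min-1.g-1
compound 2 `COc1cc(N2CCN(C(=O)CN3CCc4ccccc43)CC2)ccc1-c1cnc(C)o1` gives 160 mL.min-1.g-1
compound 3 `COc1cc(N2CCN(C(=O)Cn3ccc4ccccc43)CC2)ccc1-c1cnc(C)o1` gives 140 mL.min-1.g-1

Compound 1 gives the lowest of the three numbers in this assay, but the gaps to compound 3 and to compound 2 are both within the scatter, so the three sit together. Among the compounds with values here, the only step measured so far, a 1.1-fold lower number from compound 2 to compound 3 (0.06 log units; within the scatter), changes a group on the saturated chain carbon and stays within the scatter.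

Compound 4 `COc1cc(N2CCN(C(=O)N[C@@H](C)c3cccc4ccccc34)CC2)ccc1-n1cc(C)nn1` differs from compound 1 by 4-methyl-1H-1,2,3-triazol-1-yl in place of 3-methyl-1H-1,2,4-triazol-1-yl on an aromatic carbon. Within the data shown here, no measured step exchanges one triazole for another, so the step from compound 2 to compound 3 bears on it only as a sign that small changes elsewhere left this assay unmoved. No step beyond the scatter is therefore expected: no change at the digits printed from compound 1 to compound 4 (within the scatter) is the expected outcome. Compound 4 is estimated at 110 mL.min-1.g-1, within 60 mL.min-1.g-1 to 210 mL.min-1.g-1.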

Compound 4, intrinsic clearance in microsomes: 230 mL.min-1.g-1
Beside the measured number, compound 4's estimate is 2.1-fold (0.32 log units) below it; measured number outside the range, above it.
By their numbers in this assay, from the lowest: compounds 1, 3, 2 and 4 (each within the scatter of the next, the first and the last beyond it).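

The exchange of 3-methyl-1H-1,2,4-triazol-1-yl for 4-methyl-1H-1,2,3-triazol-1-yl, on an aromatic carbon ortho to a methoxy group, gives a 2.1-fold higher number from compound 1 to compound 4 (0.32 log units; beyond the scatter) in this assay. Within the data shown here, this is the first step beyond the scatter, and it places this position, not only the large group at the other end, among the sites that can move the read-out. The two groups have the same atoms joined differently, so a rearrangement of the ring alone is enough to produce a modest step.

Going by these compounds, how a pyrazole or a carboxylic acid at this position would compare with either triazole remains open. Nothing measured bears on the cause of the step.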